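Changing the amine substituent of compound 3

The source may hold more compounds than are shown below. What is called first, only, known or untested is meant among the compounds shown, and "the series" means these compounds.

Measured values in a functional assay on SK-BR-3 cells (Homo sapiens) for antiproliferative activity (on this read-out lower numbers stand for stronger inhibition and higher numbers for weaker inhibition), are these:
- Compound 1 `CC(C)=CCc1cc(C(=O)Nc2cc3ccc(OCCCN4CCCCC4)c(C)c3oc2=O)ccc1O` gives > 50000 nM as a limit
- Compound 2 `CCCNCCCOc1ccc2cc(NC(=O)c3ccc(O)c(CC=C(C)C)c3)c(=O)oc2c1C` gives 990 nM as a number
- Compound 3 `CC(C)=CCc1cc(C(=O)Nc2cc3ccc(OCCCNCCO)c(C)c3oc2=O)ccc1O` gives 610 nM as a number

Going by the values given here, compound 3 lies within the usual scatter of compound 2, and these two are the only true numbers so far.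

The next molecule, compound 4 `CC(C)=CCc1cc(C(=O)Nc2cc3ccc(OCCCNC4CCCCC4)c(C)c3oc2=O)ccc1O`, carries cyclohexyl in place of 2-hydroxyethyl on an amine nitrogen. Two kinds of measured step bear on this change. Exchanging one open chain on the amine for another made little difference (a 1.6-fold lower number from compound 2 to compound 3 (0.21 log units; within the scatter)). Piperidin-1-yl, by contrast, stands apart from both open-chain amines (an at least 50-fold lower number from compound 1 to compound 2 (1.70 log units; beyond the scatter); an at least 81-fold lower number from compound 1 to compound 3 (1.91 log units; beyond the scatter)). Cyclohexylamino resembles compounds 2 and 3 as an amino group bearing one substituent, yet it brings a ring, as compound 1 does. A moderate move toward a higher number, meaning weaker inhibition, therefore seems likely, and a result at a limit like that of compound 1 remains possible. The expected change is a 2.5-fold higher number from compound 3 to compound 4 (0.39 log units; beyond the scatter) in this assay as estimated here. Compound 4 is expected to give about 1500 nM, with an estimated range of 350 nM to 15000 nM as its likely span.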

Compound 4, half-maximal inhibitory concentration: 660 nM
Estimate against measurement, compound 4: 2.3-fold (0.36 log units) above; the range from low to high includes it.
By their numbers in this assay, from the lowest: compounds 3, 4 and 2 (each within the scatter of the next). At a limit, above all of these: compound 1.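

A ring on the amine nitrogen is compatible with activity in this assay: cyclohexyl, with no hydrogen-bond donor or acceptor, gives a 1.1-fold higher number from compound 3 to compound 4 (0.03 log units; within the scatter) and a 1.5-fold lower number from compound 2 to compound 4 (0.18 log units; within the scatter), so the hydroxy of compound 3 is not required at this position. What sets compound 1 apart is therefore not the presence of a ring alone, since the nitrogen lies inside the ring in piperidin-1-yl and outside it in cyclohexylamino, and the change gives an at least 75-fold lower number from compound 1 to compound 4 (1.87 log units; beyond the scatter). Compound 1 stands at a limit, so the size of that step is only a bound: the limit of > 50000 nM in this assay, at which 1 of the 4 values shown sits.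

As far as these compounds go, it remains open whether the large gap requires the ring or follows from the amine nitrogen bearing two carbon substituents besides the chain. Diethylamino, with two open chains on the nitrogen, would separate these two readings.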